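This account rests on a few compounds, and the source may have more. Where it says the series, first, only, none or still open, it means among the compounds named here.

Measured compounds:
Compound 1 `CCCCNS(=O)(=O)c1ccc(Nc2ncc3c(n2)N(c2ccn(C)n2)C(CC)C(=O)N3C)cc1` gives 4240 nM in a functional assay on K562 cells (Homo sapiens) for antiproliferative activity, read by CCK-8 assay, with a stated time of 72 h; on this read-out higher numbers stand for weaker inhibition of growth and lower numbers for stronger inhibition of growth.
Compound 2 `CC[C@@H]1C(=O)N(C)c2cnc(-n3ccc4cc(C(=O)NCC(C)C)ccc43)nc2N1C1CCCC1` gives 638 nM in this assay.

Of the two measured compounds, compound 2 stands at the lower number; compound 1 stands at a higher number, and the gap between the two lies beyond the usual scatter. The two compounds share a core but differ in several places at once, so nothing more can be said of what separates them than what their two values show.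

Compound 3 `CC[C@@H]1C(=O)N(C)c2cnc(-n3ccc4cc(C(=O)NC)ccc43)nc2N1C1CCCC1` has not yet been measured. It differs from compound 2 in one place: hydrogen in place of isopropyl on a saturated chain carbon bound to an amide-type nitrogen. The amide carrying the chain is kept, and only the chain is shortened.

Going by the values given here, no step of this kind is available among the measured compounds, so the size of the step can only be guessed. A modest weakening is expected from compound 2 to compound 3, a 1.7-fold higher number from compound 2 to compound 3 (0.24 log units; within the scatter), a step that may well lie within the scatter. Compound 3 is therefore expected to give about 1100 nM in this assay, with a plausible range from 350 nM to 3500 nM.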

Compound 3, concentration for 50% growth inhibition: 705 nM
Estimate against measurement, compound 3: 1.6-fold (0.19 log units) above; the measured number falls inside the stated range.
By their numbers in this assay, from the lowest: compounds 2 and 3 (each within the scatter of the next); then compound 1.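

In this assay, going by these compounds alone, the change from isobutylcarbamoyl to methylcarbamoyl gives a 1.1-fold higher number from compound 2 to compound 3 (0.04 log units; within the scatter), the first reading of a change at this place. The earlier pair could not offer such a reading, and compound 1 and compound 2 differ in several places at once. On this read-out, compound 2 and compound 3 cannot be told apart, so the isopropyl on the saturated chain carbon bound to an amide-type nitrogen can be replaced by hydrogen with no change in growth inhibition beyond the usual scatter, at least with the rest of compound 2 held as it is. No measurement of any other kind accompanies these values, and the result therefore stands without an explanation.

The compounds shown leave open whether the same insensitivity would extend to a longer chain, a benzyl group, or a chain ending in an amine or a carboxylic acid, since only isobutyl and methyl have been compared here. Also open, on these data alone, is what happens when the amide itself is altered, for example when the amide hydrogen gives way to a second methyl group or the whole amide gives way to a carboxylic acid.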